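Ester for Amide on a Sulfonamide Inhibitor

The compounds below may be only part of what the source reports. "The series", "measured", "known", "first", "only" and "open" are said of these compounds alone.

Of the compounds shown here, three have been measured in an assay on isolated protein for inhibition of alkaline phosphatase, tissue-nonspecific isozyme (Homo sapiens); on this read-out lower numbers stand for stronger inhibition and higher numbers for weaker inhibition. Compound 1 `COc1ccc(OC)c(S(=O)(=O)Nc2cncc(-c3ccncc3)c2)c1` gives 73 nM, compound 3 `COc1ccc(C#N)cc1S(=O)(=O)Nc1cnc2ccccc2c1` gives 38 nM, and compound 2 `COc1ccc(C(N)=O)cc1S(=O)(=O)Nc1cccnc1` gives 1490 nM, the highest of the three numbers, beyond the usual scatter from both of the others. Compound 4 `COC(=O)c1ccc(OC)c(S(=O)(=O)Nc2cccnc2)c1` keeps the core of compound 2 and differs in a single place: methoxy in place of amino on a carbonyl carbon, which read one bond further out is carbamoyl to methoxycarbonyl. Within the data shown here, no pair of measured compounds differs by this change alone, so its effect in this assay is untested. The step from compound 2 to compound 4 is expected to be modest, a 2.1-fold lower number from compound 2 to compound 4 (0.33 log units; beyond the scatter), leaning towards stronger inhibition with wide uncertainty. Compound 4 is estimated at 700 nM, within a range from 200 nM to 2500 nM.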

Compound 4, half-maximal inhibitory concentration: 1510 nM
Compound 4: middle estimate off by 2.2-fold (0.33 log units), on the low side, within the range that was stated.
By their numbers in this assay, from the lowest: compounds 3 and 1 (each within the scatter of the next); then compounds 2 and 4 (each within the scatter of the next).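

Replacing amino with methoxy on this carbonyl carbon gives a 1.0-fold higher number from compound 2 to compound 4 (0.01 log units; within the scatter) in this assay, so the change leaves no detectable difference. At this place, then, the hydrogen-bond donor of the amino group can be lost and a heavy atom gained with no effect that this read-out can separate from scatter. No measurement available here explains this result. Still open, from the compounds shown here alone, is how a carboxylic acid or an ethyl ester would read at this place, and whether methoxycarbonyl would behave the same way on the core of compound 3.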